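Substituent variation at one aromatic carbon of the shared core

A few compounds are considered here, and "the series" means these few. Any claim that something is new, unique, unknown or untested is made for them only; others in the source may bear on it.

Measured compounds in a functional assay for inhibition of sodium/hydrogen exchanger (Oryctolagus cuniculus); on this read-out lower numbers stand for stronger inhibition and higher numbers for weaker inhibition:
- compound 1, `CCOc1cc(C)c(C(=O)N=C(N)N)cc1S(C)(=O)=O`: 19 nM
- compound 2, `Cc1cc(N2CCC(N)CC2)c(S(C)(=O)=O)cc1C(=O)N=C(N)N`: 9.8 nM
- compound 3, `Cc1cc(-n2ccnc2C)c(S(C)(=O)=O)cc1C(=O)N=C(N)N`: 29 nM

Compound 3 holds the highest of the three numbers in this assay. Its nearest neighbour is compound 1, and the step of a 1.5-fold higher number from compound 1 to compound 3 (0.18 log units; within the scatter) lies within the scatter, so the two are not separated. The furthest is compound 2: the step of a 3.0-fold higher number from compound 2 to compound 3 (0.47 log units; beyond the scatter) is beyond the scatter but modest. The step of a 1.9-fold lower number from compound 1 to compound 2 (0.29 log units; within the scatter) is within the scatter.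

The next compound, compound 4, `Cc1cc(C(F)(F)F)c(S(C)(=O)=O)cc1C(=O)N=C(N)N`, is not yet measured in this assay. It differs from compound 3 in one place: trifluoromethyl in place of 2-methyl-1H-imidazol-1-yl on an aromatic carbon

Within the data shown here, two measured steps bear on this change, since each also replaces the group on the same aromatic carbon, ortho to a methylsulfonyl group: a 1.5-fold higher number from compound 1 to compound 3 (0.18 log units; within the scatter) and a 3.0-fold higher number from compound 2 to compound 3 (0.47 log units; beyond the scatter). Both are small; one is within the scatter, the other only modestly beyond it. Among the measured compounds shown here, no measured compound carries a trifluoromethyl group, so nothing speaks for a larger move. Compound 4 is therefore expected to land at 25 nM, with a range of 10 nM to 60 nM. The expected step is a 1.2-fold lower number from compound 3 to compound 4 (0.06 log units; within the scatter), within the scatter.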

Compound 4, half-maximal inhibitory concentration: 37 nM
Compound 4: the middle estimate sits 1.5-fold (0.17 log units) below what was measured, within the range that was stated.
By their numbers in this assay, from the lowest: compounds 2, 1, 3 and 4 (each within the scatter of the next, the first and the last beyond it).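

Working notes on the carbon ortho to the methylsulfonyl group, in this assay: trifluoromethyl, with no ring and no hydrogen-bond acceptors, is not separated from 2-methyl-1H-imidazol-1-yl, with its five-membered aromatic ring and two acceptors, as a 1.3-fold higher number from compound 3 to compound 4 (0.11 log units; within the scatter) shows, so neither that ring nor those acceptors are needed here to hold the number in this range. Trifluoromethyl is also not separated from ethoxy, as a 1.9-fold higher number from compound 1 to compound 4 (0.29 log units; within the scatter) shows, while only 4-aminopiperidin-1-yl stands apart from it, with a 3.8-fold higher number from compound 2 to compound 4 (0.58 log units; beyond the scatter) as a modest gap that now appears against both compound 3 and compound 4. Nothing available bears on why these groups read as they do.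

Still open, on these data alone, is whether the gap of compound 2 goes with the primary amine of its 4-aminopiperidin-1-yl group or with the piperidine ring itself, a question that an unsubstituted piperidin-1-yl or a simple open-chain amine at this carbon would address. Also open, as far as these compounds go, is how a carboxylic acid, a nitrile or a longer alkoxy chain would read at the same carbon.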